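Pyrazole in place of phenyl on a urea-bearing core

The source may report more compounds than this note shows. Statements on the series, on what has been measured and on what is new or still open speak of the compounds shown alone.

The series is built on a shared core carrying a methylurea and an amide, and the compounds differ in the aryl group attached to the benzamide ring. Compound 1 `CNC(=O)N1CCCc2ccc(NC(=O)c3cccc(-c4ccccc4)c3)cc21` carries a phenyl group there. In a functional assay on MV4-11 cells (Homo sapiens) for antiproliferative activity, with a stated time of 6 days, tested at 6.25 uM (on this read-out lower numbers stand for a weaker effect and higher numbers for a stronger effect at the one concentration tested), compound 1 gives 1.39%, the lowest of the two numbers in hand. Compound 2 `CNC(=O)N1CCCc2ccc(NC(=O)c3ccc(-c4cnn(C(C)=O)c4)cc3)cc21` carries an acetyl-substituted pyrazole instead and gives 83.8% in this assay, a number far above that of compound 1 and well beyond the usual scatter; since compound 2 differs from compound 1 in more than one place, the two values are simply set side by side. Compound 3 `CNC(=O)N1CCCc2ccc(NC(=O)c3cccc(-c4cnn(C)c4)c3)cc21` has not yet been tested in this assay. Relative to compound 1 it shows (1-methyl-1H-pyrazol-4-yl in place of phenyl on an aromatic carbon). Going by the values given here, with no single-point step between measured compounds available, the size of the move is uncertain, though the high value of compound 2 with its pyrazole suggests the step from compound 1 to compound 3 is expected to be upward and sizeable, a number 38.6 percentage points higher from compound 1 to compound 3 (beyond the scatter). Compound 3 is therefore estimated to reach about 40%, within a range from 5% to 85%.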

Compound 3, a percentage reported as inhibition, at one concentration (the size of the read-out at that concentration, not a potency): 93.5%
Estimate against measurement, compound 3: 53.5 percentage points below; measured number above the stated range.
By their numbers in this assay, from the lowest: compound 1; then compounds 2 and 3 (each within the scatter of the next).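

In this assay, going by these compounds alone, the exchange of phenyl for 1-methyl-1H-pyrazol-4-yl, on an aromatic carbon meta to a large group, gives a number 92.1 percentage points higher from compound 1 to compound 3 (beyond the scatter) and is the first change that can be read at a single place. Compound 2 could not show this, since it differs from compound 1 in more than one place, whereas here the shared core and the attachment point stay the same and the heavy-atom count of the group does not change. At this position, then, a five-membered aromatic ring with 2 hetero atoms and a six-membered aromatic ring of carbon only are far from interchangeable, although nothing available explains why the step is so large.

The compounds shown do not separate the contribution of the pyrazole ring from that of its methyl group, so it remains open whether an unsubstituted pyrazole, an ethyl group on the same nitrogen or a pyridine ring in the same place would keep the effect. Because each number comes from one concentration, they also leave open how potency changes along this step.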